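The compounds below may be only part of what the source reports. "The series", "measured", "known", "first", "only" and "open" are said of these compounds alone.

Compound 3 `COc1ccc(-c2cc3ccccc3nc2/C=C/C(=O)c2c(OC)cccc2OC)cc1` gives 3830 nM in a functional assay on SK-BR-3 cells (Homo sapiens) for antiproliferative activity, read by XTT assay, with a stated time of 72 h (on this read-out higher numbers stand for weaker inhibition and lower numbers for stronger inhibition), the lowest of the three numbers recorded so far. Compound 1 `COc1ccc(-c2cc3ccccc3nc2/C=C/C(=O)c2ccc(O)cc2)cc1` gives 3880 nM, and a 1.0-fold lower number from compound 1 to compound 3 (0.01 log units; within the scatter), so these two cannot be told apart. Compound 2 `COc1ccc(C(=O)/C=C/c2nc3ccccc3cc2-c2ccc(OC)cc2)cc1` gives 9280 nM, and a 2.4-fold lower number from compound 2 to compound 3 (0.38 log units; beyond the scatter). The remaining comparison, a 2.4-fold higher number from compound 1 to compound 2 (0.38 log units; beyond the scatter), shows that a small alteration at the hydroxyl of the aryl on the carbonyl carbon moves the number modestly.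

Compound 4 `COc1ccc(-c2cc3ccccc3nc2/C=C/C(=O)c2ccc(Br)s2)cc1` differs from compound 3 only at that same position: 5-bromothiophen-2-yl in place of 2,6-dimethoxyphenyl on a carbonyl carbon. The two measured steps that change the group on the carbonyl carbon, from compound 1 and from compound 2 to compound 3, are the ones that bear on this change; one lies within the scatter and the other is modest. Neither introduces a five-membered ring or a bromine, so the direction of any movement is not indicated by the data. The step from compound 3 to compound 4 is therefore expected to be small, at a 1.0-fold higher number from compound 3 to compound 4 (0.02 log units; within the scatter). Compound 4 is expected to give about 4000 nM in this assay, with a range from 1500 nM to 11000 nM.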

Compound 4, half-maximal inhibitory concentration: 520 nM
Compound 4: the middle estimate sits 7.7-fold (0.89 log units) above what was measured; the whole stated range lies above it.
By their numbers in this assay, from the lowest: compound 4; then compounds 3 and 1 (each within the scatter of the next); then compound 2.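

Among these compounds, the group on the carbonyl carbon turns out to have far more reach in this assay than the earlier compounds showed, as they carried only six-membered aromatic rings of carbon at this place. With 5-bromothiophen-2-yl on the carbonyl carbon there is a 7.4-fold lower number from compound 3 to compound 4 (0.87 log units; beyond the scatter) and a 7.5-fold lower number from compound 1 to compound 4 (0.87 log units; beyond the scatter) and, against the highest number of the series, an 18-fold lower number from compound 2 to compound 4 (1.25 log units; beyond the scatter) as the largest step recorded so far, which leaves compound 4 with the lowest number of the four, beyond the scatter of each of the others. The change replaces the ring and introduces bromine in a single step, so the two cannot be separated here, and nothing at hand accounts for the gain.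

As far as these compounds go, whether a plain thiophen-2-yl, a bromophenyl, or a thiophene carrying chlorine, a methyl or an amine in place of the bromine would give a similar number remains open. From the compounds shown here alone, it also remains open whether the step keeps its size with another group on the shared core, or in another cell line.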